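A few compounds are considered here, and "the series" means these few. Any claim that something is new, unique, unknown or untested is made for them only; others in the source may bear on it.

Measured so far:
compound 1, `O=C(/C=C/c1ccc(F)cc1)NS(=O)(=O)c1ccc(F)cc1`: 0.8 ug/mL
compound 2, `O=C(/C=C/c1ccc(Br)cc1)NS(=O)(=O)c1ccccc1`: 3.9 ug/mL

Both numbers come from a functional assay on B16-F10 cells (Mus musculus) for antiproliferative activity, read by ELISA and MTT assay, with a stated time of 48 h; a lower number here means a stronger inhibitor, a higher number a weaker inhibitor. Of the two, compound 2 holds the higher number, and compound 1 sits below it by a gap beyond the scatter. Compound 3, `O=C(/C=C/c1ccc(Br)cc1)NS(=O)(=O)c1ccc(F)cc1`, differs from compound 2 in one place: fluoro in place of hydrogen on an aromatic carbon. Among the compounds with values here, no pair of measured compounds separates this change on its own, so its effect is a matter of expectation. Compound 1 also carries fluoro on that ring and gives 0.8 ug/mL in this assay, which points downward. The expected step is a 2.0-fold lower number from compound 2 to compound 3 (0.29 log units; within the scatter), small and downward, perhaps not beyond the scatter. Compound 3 is therefore estimated at 2 ug/mL, within 0.7 ug/mL to 6 ug/mL.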

Compound 3, half-maximal inhibitory concentration: 1.2 ug/mL
The estimate for compound 3 lay 1.7-fold (0.22 log units) above the measured number, and the stated range covers the measured number.
By their numbers in this assay, from the lowest: compounds 1 and 3 (each within the scatter of the next); then compound 2.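

In this assay, within the data shown here, fluoro in place of hydrogen, para to a large group, gives a 3.3-fold lower number from compound 2 to compound 3 (0.51 log units; beyond the scatter) as the first direct reading of this change, and that step lies beyond the scatter. With that fluoro kept, bromo in place of fluoro on the other aromatic carbon gives a 1.5-fold higher number from compound 1 to compound 3 (0.18 log units; within the scatter) and so does not separate the two halogens. Nothing available explains either step. From the compounds shown here alone, whether chloro, methoxy or an amine at the fluoro position would give a similar number remains open. So does whether the fluoro step would recur with a different group in place of the bromo.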